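The compounds below may be only part of what the source reports. "The series", "measured", "known", "first", "only" and "open" are said of these compounds alone.

Measured compounds in a functional assay on the whole organism (strain Wistar) for inhibition, with Rattus norvegicus as the target, with stated times of 30 min and 3 h, at a dose of 20 mg/kg by the oral route; on this read-out higher numbers stand for more inhibition at the one dose given (going by the name of the read-out) and lower numbers for less inhibition:

Compound 1, `Cc1ccc(C(=O)CCc2nnc(-c3ccccc3)o2)cc1`, gives 49.3%.
Compound 2, `Cc1ccc(C(=O)CCc2nnc(-c3ccc([N+](=O)[O-])cc3)o2)cc1`, gives 60.5%.
Compound 3, `COc1ccc(-c2nnc(CCC(=O)c3ccc(C)cc3)o2)cc1`, gives 89.5%.

Compound 2 stands second of the three numbers in this assay. Compound 1 lies nearer to it, the step being a number 11.2 percentage points higher from compound 1 to compound 2 (beyond the scatter). Compound 3 lies further off, with the step of a number 29 percentage points higher from compound 2 to compound 3 (beyond the scatter); the step of a number 40.2 percentage points higher from compound 1 to compound 3 (beyond the scatter) places compound 3 highest of the three, each of its steps to the others beyond the scatter.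

Compound 4, `Cc1ccc(C(=O)CCc2nnc(-c3ccc([N+](=O)[O-])cc3)o2)c(C)c1`, has not yet been measured in this assay. The change from compound 2 to compound 4 is methyl in place of hydrogen on an aromatic carbon. This is a methyl in place of hydrogen on the ring that already carries a methyl group, ortho to a large group and meta to that methyl.

None of the three measured steps bears directly on this change: all three alter the group on the phenyl attached to the shared core, not the ring where the new methyl enters. The three measured steps were modest to large, but they concern a different place. Within the data shown here, with no step of the same kind in hand, the expectation for compound 4 is a step of a number 0.5 percentage points lower from compound 2 to compound 4 (within the scatter), within the scatter of compound 2.

Compound 4 is therefore expected to give about 60% in this assay, with a range from 45% to 75%.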

Compound 4, a percentage reported as inhibition, in the whole organism at one dose (the size of the read-out at that dose, not a potency): 69.1%
Estimate against measurement, compound 4: 9.1 percentage points below; low and high end bracket the measured number.
By their numbers in this assay, from the lowest: compound 1; then compounds 2 and 4 (each within the scatter of the next); then compound 3.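

In this assay, the change from 4-methylphenyl to 2,4-dimethylphenyl gives a number 8.6 percentage points higher from compound 2 to compound 4 (within the scatter) and so leaves the two compounds indistinguishable on this read-out. This is the only change shown on the ring that carries the methyl group, as the earlier steps all altered the group on the other phenyl, and those steps lay beyond the scatter. A methyl on this aromatic carbon, ortho to a large group and meta to the existing methyl, is therefore accepted without a difference that this read-out can resolve, and nothing in the data given accounts for the result.

The compounds shown leave open whether the same methyl would also make no clear difference alongside the methoxy group of compound 3, which gives 89.5% in this assay, or alongside the unsubstituted phenyl of compound 1. They also leave open how this position would respond to an ethyl group, a chlorine atom or an amine in place of the methyl.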